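The source may report more compounds than this note shows. Statements on the series, on what has been measured and on what is new or still open speak of the compounds shown alone.

Compound 1 `FC(F)(F)c1ccc2[nH]c(-c3ccccc3)nc2c1` is one of two compounds with a number in a functional assay on aorta (Rattus norvegicus, strain Wistar) for inhibition, with a stated time of 60 min (a higher number here means that more compound is needed for the effect, a lower number that less compound is needed), and it holds the highest of those two numbers: in this assay compound 1 gives 369000 nM. Among the compounds with values here, the nearest compound, compound 2 `CC(C)Oc1ccccc1-c1nc2cc([N+](=O)[O-])ccc2[nH]1`, gives 4890 nM in this assay, a gap that lies well beyond the scatter; the two differ in more than one place, so their values show only that compound 2 needs far less compound for the effect. Compound 3 `CN(C)c1ccc(-c2nc3cc(C(F)(F)F)ccc3[nH]2)cc1` has not been measured in this assay. It differs from compound 1 in one place: dimethylamino in place of hydrogen on an aromatic carbon. Within the data shown here, no step between measured compounds shows what such a change does here, so the expectation rests on compound 1 alone, with compound 2 as a reminder that much lower numbers are reachable within the shared core. Compound 3 is expected to move toward a lower number by a 3.1-fold lower number from compound 1 to compound 3 (0.49 log units; beyond the scatter), a step that may still fall inside the scatter. Compound 3 is therefore estimated at 120000 nM in this assay, within a range from 25000 nM to 450000 nM.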

Compound 3, half-maximal effective concentration: 550000 nM
Compound 3: middle estimate off by 4.6-fold (0.66 log units), on the low side; measured number above the stated range.
By their numbers in this assay, from the lowest: compound 2; then compounds 1 and 3 (each within the scatter of the next).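

Dimethylamino in place of hydrogen on an aromatic carbon, para to a large group, gives a 1.5-fold higher number from compound 1 to compound 3 (0.17 log units; within the scatter) in this assay. This first readable step at this position shows that the number does not respond measurably to this change: a group of 3 heavy atoms with a hydrogen-bond acceptor can stand here with no difference beyond the scatter. The low numbers seen elsewhere in the series therefore find no support in this change.

Going by these compounds, whether a primary amine, a methoxy group or a carboxylic acid in the same place would give a number apart from that of compound 1 remains open. So does the question of which of the several differences between compound 1 and compound 2 carries the gap between their numbers. Nothing measured here bears on the reason for this result.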